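This account rests on a few compounds, and the source may have more. Where it says the series, first, only, none or still open, it means among the compounds named here.

Series notes. In an ADME assay on the whole organism with Oryza sativa as the target, tested at 0.1 uM (a higher number here means a weaker effect of the compound at the concentration tested, a lower number a stronger effect), compound 1 `Cc1ccccc1NC(=O)N[C@H](C)c1ccccc1` gives 100%. Compound 2 `C[C@@H](NC(=O)Nc1ccccc1F)c1ccccc1` gives 97% in this assay, and compound 3 `C[C@@H](NC(=O)Nc1ccccc1I)c1ccccc1` gives 100%. Compound 2 stands lowest of the three numbers, but the step of a number 3 percentage points lower from compound 1 to compound 2 (within the scatter) and the step of a number 3 percentage points higher from compound 2 to compound 3 (within the scatter) are both within the scatter, as is no change at the digits printed from compound 1 to compound 3 (within the scatter), so the three compounds are not separated. Compound 4 `C[C@@H](NC(=O)Nc1c(F)cccc1F)c1ccccc1` differs from compound 2 by fluoro in place of hydrogen on an aromatic carbon. The steps bearing on this change, fluoro in place of methyl and iodo in place of fluoro on the same ring, were all small, so no step beyond the scatter is expected in this assay. The step from compound 2 to compound 4 is expected to be a number 1 percentage points higher from compound 2 to compound 4 (within the scatter). Compound 4 is estimated at 98%, within 88% to 100%.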

Compound 4, a percentage reported as activity, at one concentration (the size of the read-out at that concentration, not a potency): 100%
Compound 4: the middle estimate sits 2 percentage points below what was measured, and the stated range covers the measured number.
By their numbers in this assay, from the lowest: compounds 2, 1, 3 and 4 (each within the scatter of the next).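

Up to compound 3, only the group at a single ring position had changed; compound 4 keeps that fluoro and adds a second fluoro ortho to a large group and meta to a fluoro group. In this assay the result is a number 3 percentage points higher from compound 2 to compound 4 (within the scatter), so this added fluoro does not separate the two compounds. No measurement is available that bears on this result.

Going by these compounds, whether an amine, a carboxylic acid or a longer chain at this position would give a step beyond the scatter stays open.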